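The compounds below may be only part of what the source reports. "The series", "measured", "known", "first", "only" and "open" are said of these compounds alone.

Compound 1 `CN(CCNCc1cn(-c2ccccc2)nn1)CCNc1ccnc2cc(Cl)ccc12` — 25000 nM
Compound 2 `CN(CCNCc1cn(-c2ccc(Cl)cc2)nn1)CCNc1ccnc2cc(Cl)ccc12` — 14000 nM
Compound 3 `CN(CCNCc1cn(-c2cccc(Cl)c2)nn1)CCNc1ccnc2cc(Cl)ccc12` — 17000 nM

In a functional assay on NCI-H460 cells (Homo sapiens) for antiproliferative activity, read by sulforhodamine B assay, with a stated time of 72 h (a higher number here means a weaker inhibitor, a lower number a stronger inhibitor), compound 1 gives the highest of the three numbers; compound 3 sits nearest and compound 2 furthest, but both gaps fall within the scatter, so no real order among the three can be read from them. Compound 4 `CN(CCNCc1cn(-c2ccccc2Cl)nn1)CCNc1ccnc2cc(Cl)ccc12` differs from compound 1 by chloro in place of hydrogen on an aromatic carbon; cut one bond further out, the change reads phenyl to 2-chlorophenyl, the chloro sitting ortho to a large group. For the measured compounds named here, two measured steps bear on it, each a chloro in place of hydrogen on the same ring: a 1.8-fold lower number from compound 1 to compound 2 (0.25 log units; within the scatter) and a 1.5-fold lower number from compound 1 to compound 3 (0.17 log units; within the scatter). The comparison of the two chloro positions, a 1.2-fold higher number from compound 2 to compound 3 (0.08 log units; within the scatter), is likewise within the scatter. A chloro on this ring has so far moved this assay only within its scatter, toward a lower number. For compound 4 a step of a 1.3-fold lower number from compound 1 to compound 4 (0.10 log units; within the scatter) is therefore expected, nothing beyond the scatter. Compound 4 is estimated at 20000 nM, with a range from 10000 nM to 40000 nM.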

Compound 4, half-maximal inhibitory concentration: 20000 nM
For compound 4 middle estimate and measured number coincide at the digits printed, within the range that was stated.
By their numbers in this assay, from the lowest: compounds 2, 3, 4 and 1 (each within the scatter of the next).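

With 2-chlorophenyl in place, all three chloro placements on this ring can be read in this assay, and the one ortho to a large group also stays within the scatter (a 1.3-fold lower number from compound 1 to compound 4 (0.10 log units; within the scatter)). The chloro isomers cannot be separated from one another either (a 1.2-fold higher number from compound 3 to compound 4 (0.07 log units; within the scatter); a 1.4-fold higher number from compound 2 to compound 4 (0.15 log units; within the scatter)), so in this small set, moving the chloro around the ring gives no readable difference. No accompanying measurement speaks to why the response is this flat.

The compounds shown carry only hydrogen or a single chloro on this ring, so it remains open whether any substituent here can shift this assay beyond the scatter. An amine, a carboxylic acid or a methoxy group on the ring, or a longer chain in the linker of the shared core, would address that.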